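Pyridin-3-yl for thiophen-2-yl: a repeated swap

The source may hold more compounds than are shown below. What is called first, only, known or untested is meant among the compounds shown, and "the series" means these compounds.

Measured so far in an in vitro assay on BTI-TN-5B1-4 cells for inhibition of Amine oxidase [flavin-containing] A (Homo sapiens), read by Amplex Red, with a stated time of 15 min, tested at 100 uM; on this read-out higher numbers stand for more inhibition at the one concentration tested (going by the name of the read-out) and lower numbers for less inhibition:
compound 1 `Fc1ccc(-c2csc(N/N=C\c3cccs3)n2)cc1` gives 40%
compound 2 `Fc1ccc(-c2csc(N/N=C\c3cccnc3)n2)cc1` gives 40%
compound 3 `C/C(=N/Nc1nc(-c2ccc(F)cc2F)cs1)c1cccs1` gives 40%

Compound 2 differs from compound 1 by pyridin-3-yl in place of thiophen-2-yl on a carbon with a double bond to nitrogen, and this step, no change at the digits printed from compound 1 to compound 2 (within the scatter), left the read-out in this assay where it was. Compound 3 has a different core; how its core differs from that of compound 1 is not broken down here, and its value in this assay sits level with those of compound 1 and compound 2 within the scatter.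

Compound 4 `C/C(=N/Nc1nc(-c2ccc(F)cc2F)cs1)c1cccnc1` is not yet measured. It differs from compound 3 by pyridin-3-yl in place of thiophen-2-yl on a carbon with a double bond to nitrogen. The place is not identical: in compound 3 the carbon carrying the group also bears a saturated chain carbon, so this is the same kind of change rather than the same one. Because the earlier step of no change at the digits printed from compound 1 to compound 2 (within the scatter) was flat, the step of no change at the digits printed from compound 3 to compound 4 (within the scatter) is expected to be small as well. Compound 4 is estimated at 40%, likely between 28% and 52%.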

Compound 4, a percentage reported as inhibition, at one concentration (the size of the read-out at that concentration, not a potency): 40%
Compound 4: middle estimate and measured number agree at the digits printed; the measured number falls inside the stated range.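

In this assay, pyridin-3-yl in place of thiophen-2-yl on a second core, where the carbon with a double bond to nitrogen also bears a saturated chain carbon, gave no change at the digits printed from compound 3 to compound 4 (within the scatter). The swap behaved alike on both cores: the same change on two cores in this assay, no change at the digits printed (within the scatter) from compound 1 to compound 2 and no change at the digits printed (within the scatter) from compound 3 to compound 4, 0 percentage points apart, within the scatter of two such steps. This shows that the swap leaves the read-out flat on these two cores at the one concentration tested, but these percentages are not potencies, so it does not show that the two groups are interchangeable on other cores, at other concentrations or in other assays.

The compounds shown leave open whether a different group in this place, such as a carboxylic acid or a longer chain, would move the read-out beyond the scatter.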